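Amide methylation, compound 3 to compound 4

A few compounds are considered here, and "the series" means these few. Any claim that something is new, unique, unknown or untested is made for them only; others in the source may bear on it.

Among the measured compounds shown here, compound 1 `COCc1ccc(-c2ccc3nnc(C(N)=O)c(N[C@@H](C)c4nn(C)cc4C)c3c2)cn1` is the most lipophilic of the three measured members: in a physicochemical assay for lipophilicity, using the shake flask method, measured as octanol-water partition, with a stated time of 30 min, at pH 7.4 (on this read-out higher numbers stand for higher lipophilicity and lower numbers for lower lipophilicity), compound 1 gives 2.8. Compound 2 `C[C@H](Nc1c(C(N)=O)nnc2ccc(-c3ccc(OCCCN(C)C)nc3)cc12)C1CCOCC1` gives 1.9, and compound 3 `Cc1cn(C)nc1[C@H](C)Nc1c(C(N)=O)nnc2ccc(-c3ccc(OCCCN(C)C)nc3)cc12` gives 2.1. On these numbers compound 3 stands second highest; its nearest neighbour is compound 2, and the step of a number 0.20 log units higher from compound 2 to compound 3 (within the scatter) lies within the scatter, whereas the step of a number 0.70 log units lower from compound 1 to compound 3 (beyond the scatter) is modest but beyond it.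

Compound 4 `CNC(=O)c1nnc2ccc(-c3ccc(OCCCN(C)C)nc3)cc2c1N[C@@H](C)c1nn(C)cc1C` differs from compound 3 by methyl in place of hydrogen on an amide-type nitrogen, which one bond further out reads carbamoyl to methylcarbamoyl. Neither measured step touches this position: a number 0.70 log units lower from compound 1 to compound 3 (beyond the scatter) concerns the side chain on the aromatic carbon, and a number 0.20 log units higher from compound 2 to compound 3 (within the scatter) concerns the group on the saturated chain carbon bound to the ring nitrogen. For the measured compounds named here, no measured step therefore bears directly on the change in hand, and the expectation rests on the entering methyl alone. A small rise, at most just beyond the scatter, is expected rather than a fall. The step from compound 3 to compound 4 is estimated as a number 0.30 log units higher from compound 3 to compound 4 (within the scatter). Compound 4 is accordingly estimated at 2.4, with a range from 2 to 2.9.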

Compound 4, distribution coefficient: 2.3
Compound 4: the middle estimate sits 0.10 log units above what was measured; measured number inside the range.
By their numbers in this assay, from the lowest: compounds 2, 3 and 4 (each within the scatter of the next, the first and the last beyond it); then compound 1.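

In this assay, among the compounds shown here, the change on the amide-type nitrogen reads a number 0.20 log units higher from compound 3 to compound 4 (within the scatter) and gives the first direct reading at this position, as the earlier steps concerned other places. Methyl in place of hydrogen, read one bond further out as carbamoyl to methylcarbamoyl, adds one carbon, no ring and no net charge, yet leaves compound 3 and compound 4 within the scatter of each other on this read-out, and this rests on a single matched pair. No evidence in hand accounts for the size of this step.

Still open, going by these compounds, is how the read-out responds to larger changes on the same nitrogen: an ethyl group, a longer chain, a cyclopropyl group or a second methyl would show whether any step there goes beyond the scatter. Also open, on these data alone, is whether the same methyl gives a step of like size with the methoxymethyl group of compound 1 or the oxan-4-yl group of compound 2, which this one pair cannot show.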